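Swapping the chain on a weak antiproliferative series

A few compounds are considered here, and "the series" means these few. Any claim that something is new, unique, unknown or untested is made for them only; others in the source may bear on it.

Measured so far:
compound 1 `C=CCCCn1c(Cc2cc(OC)c(OC)c(OC)c2)nc2c(N)nc(F)nc21`: 44700 nM
compound 2 `COc1cc(Cc2nc3c(N)ncnc3n2CCOC(C)C)cc(OC)c1OC`: 38900 nM
compound 3 `CCCCn1c(Cc2cc(OC)c(OC)c(OC)c2Br)nc2c(N)ncnc21`: 25100 nM

All three compounds were tested in a functional assay on MCF7 cells (Homo sapiens) for antiproliferative activity; on this read-out lower numbers stand for stronger inhibition and higher numbers for weaker inhibition. Compound 1 shows the largest number of the three, yet compound 2 and compound 3 both lie within the usual scatter of it, so the three cannot really be told apart; each is a weak inhibitor.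

The unmeasured compound 4 `COCCn1c(Cc2cc(OC)c(OC)c(OC)c2)nc2c(N)nc(F)nc21` keeps the core of compound 1 and changes only the chain on the aromatic nitrogen: methoxy in place of allyl on a saturated chain carbon, two bonds along the chain from an aromatic nitrogen. For the measured compounds named here, no pair of measured compounds differs in a single place, so no measured step guides this change directly. Compound 2 carries a chain with an oxygen in it and gives a number in this assay close to compound 1, which suggests that placing an oxygen in the chain does not move the read-out far.

Compound 4 is therefore expected to stay near compound 1, with a step of a 1.1-fold lower number from compound 1 to compound 4 (0.05 log units; within the scatter) of no clear direction beyond the scatter. The estimate for compound 4 in this assay is 40000 nM, expected between 15000 nM and 100000 nM, because compound 1 gives 44700 nM and compound 2 gives 38900 nM.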

Compound 4, half-maximal inhibitory concentration: 64600 nM
Compound 4: the middle estimate sits 1.6-fold (0.21 log units) below what was measured, within the range that was stated.
By their numbers in this assay, from the lowest: compounds 3, 2, 1 and 4 (each within the scatter of the next, the first and the last beyond it).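

For the compounds shown here, this is the first step that changes one place only: methoxy in place of allyl on a saturated chain carbon, two bonds along the chain from an aromatic nitrogen, gives a 1.4-fold higher number from compound 1 to compound 4 (0.16 log units; within the scatter) in this assay. On the core of compound 1, then, a chain ending in allyl and a chain carrying methoxy cannot be told apart at this place, and both compounds remain weak inhibitors. No measured property bears on this result.

The compounds shown leave open whether an amine, a carboxylic acid or a much longer chain at this place would give a clearly different number. They also leave open whether the same swap would read alike on the core of compound 3.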